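Benzyl substituent swap in a cytotoxicity series

The source may report more compounds than this note shows. Statements on the series, on what has been measured and on what is new or still open speak of the compounds shown alone.

Two members of the series have been run in a functional assay on K562 cells (Homo sapiens) for cytotoxicity, read by MTT assay, with a stated time of 48 h; on this read-out higher numbers stand for weaker inhibition and lower numbers for stronger inhibition. Within the data shown here, compound 1 `COc1ccc(CN2C(=O)C(=O)c3cc(/C=C/C(=O)OC(C)(C)C)ccc32)cc1` gives 50 nM in this assay, the higher of the two numbers so far. Compound 2 `COC(=O)/C=C/c1ccc2c(c1)C(=O)C(=O)N2Cc1ccc(C)cc1` gives 40 nM in this assay; the gap between compound 2 and compound 1 lies within the scatter, so the two stand level and no order can be read from them. Compound 3 `CC(C)(C)OC(=O)/C=C/c1ccc2c(c1)C(=O)C(=O)N2Cc1ccc(Br)cc1` is not yet measured. Relative to compound 1 it differs in one place: bromo in place of methoxy on an aromatic carbon. Among the measured compounds shown here, no pair of measured compounds carries a change of this kind, so there is no precedent for it in this assay. For compound 3 the expected step is small, with no direction beyond the scatter: a 1.1-fold lower number from compound 1 to compound 3 (0.05 log units; within the scatter). Compound 3 is accordingly estimated at 45 nM, with a range from 20 nM to 110 nM.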

Compound 3, half-maximal inhibitory concentration: 290 nM
Compound 3: middle estimate off by 6.4-fold (0.81 log units), on the low side; the whole stated range lies below it.
By their numbers in this assay, from the lowest: compounds 2 and 1 (each within the scatter of the next); then compound 3.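

Notes on the benzyl position: with the rest of the structure unchanged, the swap from 4-methoxybenzyl to 4-bromobenzyl moves the read-out in this assay, giving a 5.8-fold higher number from compound 1 to compound 3 (0.76 log units; beyond the scatter). This single-place pair shows that the substituent on the aromatic carbon para to a large group is not neutral in this assay, and that bromo in place of methoxy goes with weaker inhibition. No supporting data on the origin of this step are available.

One pair cannot separate the effect of losing methoxy from that of gaining bromo; a chloro group, an amine or a carboxylic acid at the same place would help to tell these apart. Going by these compounds, whether the step carries over to compounds with a methyl ester, as in compound 2, also remains open.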